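Ethoxy in Place of Methyl on a Carbonyl Carbon

The compounds below may be only part of what the source reports. "The series", "measured", "known", "first", "only" and "open" are said of these compounds alone.

In a functional assay (trachea) with Cavia porcellus as the target (a lower number here means a stronger inhibitor, a higher number a weaker inhibitor), compound 1 `CCCn1nc(-c2cccnc2)c2ccccc2c1=O` gives 3160 nM and compound 2 `C=CCn1nc(-c2cccnc2)c2ccccc2c1=O` gives 2140 nM. The step between them, a 1.5-fold lower number from compound 1 to compound 2 (0.17 log units; within the scatter), stays within the scatter. Compound 3 `CC(=O)Cn1nc(-c2cccnc2)c2ccccc2c1=O` gives 40700 nM, the highest of the three numbers and so the weakest inhibitor of the set. Two large steps lead to it: a 13-fold higher number from compound 1 to compound 3 (1.11 log units; beyond the scatter) and a 19-fold higher number from compound 2 to compound 3 (1.28 log units; beyond the scatter).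

Compound 4 `CCOC(=O)Cn1nc(-c2cccnc2)c2ccccc2c1=O` differs from compound 3 by ethoxy in place of methyl on a carbonyl carbon, which reads equally as acetyl to ethoxycarbonyl: ethoxy in place of methyl on a carbonyl carbon. Among the compounds with values here, no measured step makes this exchange, so the evidence is indirect. The two large steps both introduce the acetyl group, and compound 4 keeps the carbonyl on the same saturated chain carbon. It is therefore expected to stay close to compound 3 at 40700 nM rather than return to the values of compound 1 and compound 2. Within the data shown here, with only three measured compounds, a partial return cannot be excluded, and the expected range is wide on that account. The estimate is a small move, a 1.6-fold lower number from compound 3 to compound 4 (0.21 log units; within the scatter). For compound 4 the expected value is 25000 nM, with an estimated range from 6000 nM to 80000 nM.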

Compound 4, half-maximal inhibitory concentration: 43700 nM
For compound 4 the middle estimate is 1.7-fold (0.24 log units) below the measured one; measured number inside the range.
By their numbers in this assay, from the lowest: compounds 2 and 1 (each within the scatter of the next); then compounds 3 and 4 (each within the scatter of the next).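

In this assay, ethoxy in place of methyl on a carbonyl carbon gives a 1.1-fold higher number from compound 3 to compound 4 (0.03 log units; within the scatter), so acetyl and ethoxycarbonyl cannot be told apart here, even though the entering group brings more heavy atoms and a hydrogen-bond acceptor. The second carbonyl group also stands well apart from the groups without a carbonyl, with a 20-fold higher number from compound 2 to compound 4 (1.31 log units; beyond the scatter) and a 14-fold higher number from compound 1 to compound 4 (1.14 log units; beyond the scatter), both large steps; among these four compounds, the two carrying a carbonyl on the saturated chain carbon bound to an aromatic nitrogen are the two with the high numbers, and no compound goes against this. No measured property of these compounds offers an explanation for this result.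

The compounds shown leave open whether the high numbers follow the carbonyl itself, since a carboxylic acid or a primary amide on that saturated chain carbon could either stay with compound 3 and compound 4 or fall back toward compound 1 and compound 2. They also leave open how a longer alkyl chain or an amine at the same place would read in this assay.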